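Lengthening the alkoxy chain on a pyridine-linked bicyclic amine

The source may hold more compounds than are shown below. What is called first, only, known or untested is meant among the compounds shown, and "the series" means these compounds.

Measured so far:
- compound 1 `C/C=C\Oc1cncc(N2C3CCNCC2CC3)c1`: 3.1 nM
- compound 2 `COc1cncc(N2C3CCNCC2CC3)c1`: 10 nM

Both compounds share a core and differ only in the group on the oxygen attached to the aromatic ring. In an assay (strain Wistar) for binding affinity to Neuronal acetylcholine receptor; alpha4/beta2 (Rattus norvegicus) (a higher number here means a weaker inhibitor, a lower number a stronger inhibitor), compound 2 gives 10 nM, the highest of the two numbers; its nearest neighbour is compound 1, and the step of a 3.2-fold higher number from compound 1 to compound 2 (0.51 log units; beyond the scatter) is beyond the scatter, so compound 2 binds less tightly.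

Compound 3 `CCOc1cncc(N2C3CCNCC2CC3)c1` is the next member of this small set. It differs from compound 2 by methyl in place of hydrogen on a saturated chain carbon bound to an oxygen on an aromatic ring; read one bond further out, methoxy becomes ethoxy.

Within the data shown here, only one measured step bears on this change: the step of a 3.2-fold higher number from compound 1 to compound 2 (0.51 log units; beyond the scatter), which shows that a larger group on the oxygen went with a lower number. Ethoxy sits between methoxy and prop-1-en-1-yloxy in size, so a modest fall in this assay, smaller than that step, is expected. Compound 3 is therefore estimated at 5.5 nM, within 2.2 nM to 14 nM, and the expected step is a 1.8-fold lower number from compound 2 to compound 3 (0.26 log units; within the scatter).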

Compound 3, half-maximal inhibitory concentration: 3 nM
The estimate for compound 3 lay 1.8-fold (0.26 log units) above the measured number; measured number inside the range.
By their numbers in this assay, from the lowest: compounds 3 and 1 (each within the scatter of the next); then compound 2.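

In this assay, the single added methyl that turns the methoxy group of compound 2 into the ethoxy group of compound 3 gives a 3.3-fold lower number from compound 2 to compound 3 (0.52 log units; beyond the scatter) and so counts for something at this position, even though only 1 carbon changes. The other new comparison, a 1.0-fold lower number from compound 1 to compound 3 (0.01 log units; within the scatter), puts the ethyl group of compound 3 level with the prop-1-en-1-yl group of compound 1, so this assay does not separate these two groups on the oxygen. The earlier pair showed only that methyl went with a higher number than prop-1-en-1-yl; the new compound shows that a saturated ethyl group closes that whole gap, and that the double bond of compound 1 is not needed to reach this level.

Nothing measured here explains why the methyl-to-ethyl change matters. The compounds shown leave open whether a longer chain such as propyl or butyl, a branched isopropyl group or a cyclopropylmethyl group on the same oxygen would keep this level or move the number again.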